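Moving the methoxy group within the shared core

The source may hold more compounds than are shown below. What is called first, only, known or untested is meant among the compounds shown, and "the series" means these compounds.

Compound 1 `COc1ccc(C2=NN(c3ccccc3Cl)C(c3cccc(Cl)c3)C2)cc1` carries on its shared core a 2-chlorophenyl group, a 3-chlorophenyl group and a 4-methoxyphenyl group, the last on a carbon with a double bond to nitrogen. In a functional assay on HCT-116 cells (Homo sapiens) for cytotoxicity, read by a luciferase reporter and CellTiter-Glo, with a stated time of 72 h (on this read-out lower numbers stand for stronger inhibition and higher numbers for weaker inhibition), compound 1 gives 1500 nM. Compound 2 `COc1ccc(C2=NN(c3ccccc3Cl)C(c3ccccc3Cl)C2)cc1`, which carries a second 2-chlorophenyl group in place of the 3-chlorophenyl group, has no result in this assay: "not determined" (no result reported). Within the data shown here, compound 1 thus stands alone with the single number measured so far, and no measured pair shows how large a change in potency any single structural move produces.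

Compound 3 `COc1ccccc1C1=NN(c2ccccc2Cl)C(c2cccc(Cl)c2)C1` differs from compound 1 in one place: 2-methoxyphenyl in place of 4-methoxyphenyl on a carbon with a double bond to nitrogen. Among the measured compounds shown here, with no measured step to lean on, the expectation is a modest step, a 1.7-fold higher number from compound 1 to compound 3 (0.22 log units; within the scatter), leaning toward weaker inhibition but not clearly beyond the scatter of this assay. Compound 3 is accordingly estimated at 2500 nM in this assay, with a range from 800 nM to 8000 nM, and the chance that only a limit is reported instead of a number is judged small.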

Compound 3, half-maximal inhibitory concentration: 1900 nM
Beside the measured number, compound 3's estimate is 1.3-fold (0.12 log units) above it; the range from low to high includes it.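

The methoxy group can stand in either of these two arrangements on the carbon with a double bond to nitrogen without a step beyond the scatter: in this assay, 2-methoxyphenyl in place of 4-methoxyphenyl gives a 1.3-fold higher number from compound 1 to compound 3 (0.10 log units; within the scatter). Among these compounds, this is the first measured step, and it shows that, for this pair, the read-out does not separate the two methoxyphenyl groups, so the activity of compound 1 does not depend on the 4-methoxyphenyl arrangement specifically. No measurement at hand offers an explanation for this result.

The compounds shown leave open whether 3-methoxyphenyl, or a different group at this place such as a hydroxyl, an amine or a carboxylic acid, would also stay within the scatter of compound 1 and compound 3. Also open is how much the 3-chlorophenyl group contributes, since compound 2, the only compound shown with a change at that place, has no number in this assay.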